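This account rests on a few compounds, and the source may have more. Where it says the series, first, only, none or still open, it means among the compounds named here.

Measured so far:
- Compound 1 `COc1cc(-c2nc3cc(/C=C4\SC(=O)N(CC(=O)N5CCCCC5)C4=O)ccc3[nH]2)cc(OC)c1OC`: 23300 nM in a functional assay on HeLa cells (Homo sapiens) for inhibition, read by MTT assay, with a stated time of 48 h; on this read-out higher numbers stand for weaker inhibition and lower numbers for stronger inhibition
- Compound 2 `COc1cc(-c2nc3cc(/C=C4\SC(=O)N(CC(=O)N5CCCC5)C4=O)ccc3[nH]2)cc(OC)c1OC`: 4780 nM in this assay

Of these two, compound 2 holds the lower number, and the gap to compound 1 is beyond the scatter: the change from piperidin-1-yl to pyrrolidin-1-yl on the carbonyl carbon gave a 4.9-fold lower number from compound 1 to compound 2 (0.69 log units; beyond the scatter).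

Compound 3 `COc1cc(CN2C(=O)S/C(=C\c3ccc4[nH]c(-c5cc(OC)c(OC)c(OC)c5)nc4c3)C2=O)cc(OC)c1OC` is not yet measured. Its difference from compound 2 is 3,4,5-trimethoxyphenyl in place of (pyrrolidin-1-yl)carbonyl on a saturated chain carbon bound to an amide-type nitrogen in a ring. The whole amide arm is thus exchanged for an aromatic ring carrying three methoxy groups, the same kind of ring that already sits on the shared core.

Among the measured compounds shown here, the only measured step, from compound 1 to compound 2, concerns the size of the saturated ring on the amide and says nothing about removing the amide altogether, so it gives little guidance here. Without a comparable measured change, no step beyond the scatter is expected in either direction, but the uncertainty is wide. For compound 3 the expected step is a 1.0-fold higher number from compound 2 to compound 3 (0.02 log units; within the scatter), and the estimated value is 5000 nM with a range from 1000 nM to 25000 nM.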

Compound 3, half-maximal inhibitory concentration: 2240 nM
Compound 3: the middle estimate sits 2.2-fold (0.35 log units) above what was measured; measured number inside the range.
By their numbers in this assay, from the lowest: compound 3; then compound 2; then compound 1.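

In this assay, the amide arm turns out not to be required at this position: putting 3,4,5-trimethoxyphenyl in place of (pyrrolidin-1-yl)carbonyl on the saturated chain carbon gave a 2.1-fold lower number from compound 2 to compound 3 (0.33 log units; beyond the scatter). Set against the (piperidin-1-yl)carbonyl arm, the same kind of exchange gave a 10-fold lower number from compound 1 to compound 3 (1.02 log units; beyond the scatter), so a swap of the whole group moves the number further than the change in saturated ring size alone, and an aromatic ring with more heavy atoms is accepted here with a lower number than either amide. Nothing available explains why the number falls at this position.

The compounds shown leave open whether the three methoxy groups matter or whether the aromatic ring alone is enough, a question that a plain phenyl ring or a ring with a single methoxy group on this carbon would address. They also leave open how this position responds to quite different groups, such as a carboxylic acid or a longer chain ending in an amine.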